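The source may hold more compounds than are shown below. What is called first, only, known or untested is meant among the compounds shown, and "the series" means these compounds.

Compound 1 `O=C1C=C(Nc2ccc(Br)cc2)C(=O)c2c1nc1n2[C@H]2OC[C@@H](O)[C@H]2OC1` gives the lowest of the three numbers measured in a functional assay on MGC-803 cells (Homo sapiens) for inhibition, read by sulforhodamine B assay (on this read-out lower numbers stand for stronger inhibition and higher numbers for weaker inhibition), at 1010 nM. Compound 2 `O=C1C=C(Nc2ccc(C(F)(F)F)cc2)C(=O)c2c1nc1n2[C@H]2OC[C@@H](O)[C@H]2OC1` gives 2820 nM and compound 3 `CCOc1ccccc1NC1=CC(=O)c2nc3n(c2C1=O)[C@H]1OC[C@@H](O)[C@H]1OC3` gives 2450 nM. The step of a 2.8-fold higher number from compound 1 to compound 2 (0.45 log units; beyond the scatter) and the step of a 2.4-fold higher number from compound 1 to compound 3 (0.38 log units; beyond the scatter) are both beyond the scatter and modest, while the step of a 1.2-fold lower number from compound 2 to compound 3 (0.06 log units; within the scatter) stays within the scatter. Compound 4 `O=C1C=C(N2CCCC2)C(=O)c2c1nc1n2[C@H]2OC[C@@H](O)[C@H]2OC1` differs from compound 1 by pyrrolidin-1-yl in place of (4-bromophenyl)amino on a double-bonded ring carbon. Both measured steps from compound 1 alter only the aromatic ring attached to the amine nitrogen and keep the (4-bromophenyl)amino arrangement of one hydrogen-bond donor and one aromatic ring; here the aromatic ring and the donor leave altogether and pyrrolidin-1-yl enters at the double-bonded ring carbon. Among the compounds with values here, no measured step covers a change of this kind. Since both changes seen so far at this carbon, a 2.8-fold higher number from compound 1 to compound 2 (0.45 log units; beyond the scatter) and a 2.4-fold higher number from compound 1 to compound 3 (0.38 log units; beyond the scatter), gave higher numbers, a further rise is expected, probably somewhat larger, and the step of a 3.5-fold higher number from compound 1 to compound 4 (0.54 log units; beyond the scatter) is the estimate. Compound 4 is accordingly expected near 3500 nM, within 1000 nM to 12000 nM.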

Compound 4, half-maximal inhibitory concentration: > 16000 nM
Compound 4 ended at the assay's limit; the forecaster's own chance of this, stated with the estimate: 10%; middle value at least 4.5-fold (0.66 log units) from the limit.
By their numbers in this assay, from the lowest: compound 1; then compounds 3 and 2 (each within the scatter of the next). At a limit, above all of these: compound 4.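

In this assay the reading of compound 4 is a limit and not a number: the limit of > 16000 nM in this assay, at which 1 of the 4 values shown sits. Even so, an at least 15-fold higher number from compound 1 to compound 4 (1.19 log units; beyond the scatter) is the first large step in the series, while changes confined to the aromatic ring on the amine nitrogen gave only modest ones, a 2.8-fold higher number from compound 1 to compound 2 (0.45 log units; beyond the scatter) and a 2.4-fold higher number from compound 1 to compound 3 (0.38 log units; beyond the scatter). At this double-bonded ring carbon, the three compounds with an aromatic ring on an amine nitrogen (compounds 1, 2 and 3) thus stay well clear of the limit, whereas pyrrolidin-1-yl, with no aromatic ring and no hydrogen-bond donor, reaches it.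

The aromatic ring and the donor leave together in compound 4, and the compounds shown do not separate the two. A methyl(phenyl)amino group would keep the ring without the donor, and a cyclopentylamino group would keep the donor without the aromatic ring.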